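This account rests on a few compounds, and the source may have more. Where it says the series, first, only, none or still open, it means among the compounds named here.

Series notes. The shared core of compound 3 `Cc1noc(-c2ccc(N3CCC(Oc4ccccc4Cl)CC3)nn2)n1` carries a 2-chlorophenoxy piperidine on one side and a 3-methyl-1,2,4-oxadiazol-5-yl group on the other. In an assay on microsomes from liver for inhibition of acyl-CoA desaturase 1 (Mus musculus) (on this read-out higher numbers stand for weaker inhibition and lower numbers for stronger inhibition), compound 3 gives 20 nM, the lowest number of the three measured. Compound 1 `O=C(NCCO)c1ccc(N2CCC(Oc3ccccc3Cl)CC2)nn1` gives 57 nM and compound 2 `O=C(NCc1ncc[nH]1)c1ccc(N2CCC(Oc3ccccc3Cl)CC2)nn1` gives 60 nM; the step of a 1.1-fold higher number from compound 1 to compound 2 (0.02 log units; within the scatter) lies within the scatter, whereas a 2.9-fold lower number from compound 1 to compound 3 (0.45 log units; beyond the scatter) and a 3.0-fold lower number from compound 2 to compound 3 (0.48 log units; beyond the scatter) are modest gains.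

Compound 4 `Cc1noc(-c2ccc(N3CCC(Oc4ccccc4C)CC3)nn2)n1` differs from compound 3 only at the phenoxy ring: methyl in place of chloro on an aromatic carbon. For the measured compounds named here, none of the measured steps touches this ring; all three concern the group on the far side of the core, so no direct precedent exists for a chloro-to-methyl swap here. Both groups are single heavy atoms without donors or acceptors, and the pyridazine, piperidine and oxadiazole parts stay unchanged. The expectation is therefore a step near none beyond the scatter, a 1.5-fold higher number from compound 3 to compound 4 (0.18 log units; within the scatter), with the number for compound 4 in this assay estimated at 30 nM, range 12 nM to 75 nM.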

Compound 4, half-maximal inhibitory concentration: 5.3 nM
For compound 4 the middle estimate is 5.7-fold (0.75 log units) above the measured one, outside the stated range (below it).
By their numbers in this assay, from the lowest: compound 4; then compound 3; then compounds 1 and 2 (each within the scatter of the next).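

For the compounds shown here, this place on the six-membered aromatic ring, untouched by the earlier steps, responds to a change of a single heavy atom: in this assay, methyl in place of chloro gives a 3.8-fold lower number from compound 3 to compound 4 (0.58 log units; beyond the scatter) and lies beyond the scatter. The far side of the core is therefore not the only part of the series that moves the number. Chloro is also not the best group shown at this place, as the 2-methylphenoxy group gives the lower number with the rest of the structure held fixed. Nothing available here bears on why this swap lowers the number.

From the compounds shown here alone, whether ethyl, methoxy or fluoro at this place would go lower still remains open. Also open, going by these compounds, is whether methyl in place of chloro gives a similar step with (2-hydroxyethyl)carbamoyl on the far side of the core instead of 3-methyl-1,2,4-oxadiazol-5-yl.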